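Replacing the benzoxazolyl sulfide of compound 1 with a methylpiperazine

The source may report more compounds than this note shows. Statements on the series, on what has been measured and on what is new or still open speak of the compounds shown alone.

Measured compounds:
compound 1 `Cc1ccc2oc(SCC(=O)Nc3ccc(-c4nc(-c5ccccc5)c(-c5ccccc5)n4C)cc3)nc2c1` gives 22.4 ug/mL
compound 2 `Cn1c(-c2ccc(NC(=O)CSC3=NCCS3)cc2)nc(-c2ccccc2)c1-c1ccccc1` gives 21 ug/mL

Of the compounds shown here, two have been measured in a functional assay on HT-29 cells (Homo sapiens) for cytotoxicity, read by MTT assay, with a stated time of 24 h; on this read-out higher numbers stand for weaker inhibition and lower numbers for stronger inhibition. Compound 1 holds the highest of the two numbers, but compound 2 lies within the scatter of it, so the two cannot be ordered. Among the compounds with values here, the one measured step, a 1.1-fold lower number from compound 1 to compound 2 (0.03 log units; within the scatter), exchanges the group on the sulfur for a smaller saturated heterocycle and leaves the number where it was.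

Compound 3 `CN1CCN(CC(=O)Nc2ccc(-c3nc(-c4ccccc4)c(-c4ccccc4)n3C)cc2)CC1` has not yet been measured. It differs from compound 1 by 4-methylpiperazin-1-yl in place of (5-methyl-1,3-benzoxazol-2-yl)sulfanyl on a saturated chain carbon bound to a carbonyl carbon. The step from compound 1 to compound 2 is the only one that bears on this change, since it also swaps the group hanging off the acetamide chain; it stayed within the scatter. The change to compound 3 goes further, removing the sulfur altogether, so the reference is imperfect, but nothing measured points toward a shift beyond the scatter. Compound 3 is therefore expected to show a 1.1-fold higher number from compound 1 to compound 3 (0.05 log units; within the scatter). The estimate for compound 3 in this assay is 25 ug/mL, with a range from 10 ug/mL to 60 ug/mL.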

Compound 3, half-maximal inhibitory concentration: 35.5 ug/mL
The estimate for compound 3 lay 1.4-fold (0.15 log units) below the measured number, and the stated range covers the measured number.
By their numbers in this assay, from the lowest: compounds 2, 1 and 3 (each within the scatter of the next).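

In this assay, the step to 4-methylpiperazin-1-yl on a saturated chain carbon bound to a carbonyl carbon reads as a 1.6-fold higher number from compound 1 to compound 3 (0.20 log units; within the scatter) and, against the smaller ring of compound 2, as a 1.7-fold higher number from compound 2 to compound 3 (0.23 log units; within the scatter); both lie within the scatter. Compounds 1 and 2 both carry a sulfur on this chain carbon and so could not show what happens without one, whereas compound 3 carries neither that sulfur nor an aromatic ring in this group, and its number still cannot be told apart from theirs. Nothing measured here accounts for these numbers.

All three groups therefore give numbers within the scatter of their neighbours, and the compounds shown do not reveal any group at this place that moves the number beyond it. From the compounds shown here alone, it remains open whether a carboxylic acid or a primary amine on this chain carbon, or a longer chain carrying the 4-methylpiperazin-1-yl, would do so, and whether the methyl on the piperazine matters at all.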